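The compounds below may be only part of what the source reports. "The series", "measured", "known", "first", "only" and "open" are said of these compounds alone.

Compound 1 `Nc1ccccc1NC(=O)c1ccc(COc2ccc([N+](=O)[O-])cc2)cc1`: > 32000 nM (a limit of the assay)
Compound 2 `Nc1ccccc1NC(=O)c1ccc(COc2ccc(Br)cc2)cc1`: 24400 nM
Compound 3 `Cc1ccc(OCc2ccc(C(=O)Nc3ccccc3N)cc2)cc1`: 5430 nM

In a functional assay on A549 cells (Homo sapiens) for antiproliferative activity, read by CCK-8 assay, with a stated time of 72 h (a lower number here means a stronger inhibitor, a higher number a weaker inhibitor), compound 3 has the lowest of the two actual numbers, and compound 2 is its nearest neighbour. Compound 4 `COc1ccc(OCc2ccc(C(=O)Nc3ccccc3N)cc2)cc1` differs from compound 3 by one change: methoxy in place of methyl on an aromatic carbon. Two measured steps at that carbon bear on it: a 4.5-fold lower number from compound 2 to compound 3 (0.65 log units; beyond the scatter) and an at least 5.8-fold lower number from compound 1 to compound 3 (0.77 log units; beyond the scatter). Both lie beyond the scatter, but neither involves methoxy, so they give a size and no direction. The expected 1.3-fold higher number from compound 3 to compound 4 (0.11 log units; within the scatter) is therefore small, possibly within the scatter, and could go either way. Compound 4 is estimated at 7000 nM, within a range of 2200 nM to 22000 nM.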

Compound 4, half-maximal inhibitory concentration: 5530 nM
The estimate for compound 4 lay 1.3-fold (0.10 log units) above the measured number; low and high end bracket the measured number.
By their numbers in this assay, from the lowest: compounds 3 and 4 (each within the scatter of the next); then compound 2. At a limit, above all of these: compound 1.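

In this assay methoxy on this aromatic carbon, para to a large group, cannot be told from methyl, with a 1.0-fold higher number from compound 3 to compound 4 (0.01 log units; within the scatter) for the swap. Bromo gives way to methoxy with a 4.4-fold lower number from compound 2 to compound 4 (0.64 log units; beyond the scatter) as the step, much as it gave way to methyl, so both groups stand apart from bromo here. The step with an at least 5.7-fold lower number from compound 1 to compound 4 (0.76 log units; beyond the scatter) is a floor only, compound 1 standing at a limit of the assay: the limit of > 32000 nM in this assay, at which 1 of the 4 values shown sits. As far as these compounds go, whether an amine, a hydroxyl or a longer alkoxy chain on this carbon would side with methoxy and methyl or with bromo stays open.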